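Shifting a Chlorine Within the Chlorophenyl Carbonyl Group

The source may report more compounds than this note shows. Statements on the series, on what has been measured and on what is new or still open speak of the compounds shown alone.

Compound 1 `CCCCCCCCC(=O)N1c2ccccc2CCC1C(=O)Nc1ccccc1C(F)(F)F` gives 4320 nM in a functional assay on PC-3 cells (Homo sapiens) for cytotoxicity, read by sulforhodamine B assay, with a stated time of 72 h; a higher number here means a weaker inhibitor of growth, a lower number a stronger inhibitor of growth. Compound 2 `O=C(Nc1ccccc1)C1CCc2ccccc2N1` gives 110000 nM in this assay. Compound 3 `O=C(Nc1cc(C(F)(F)F)cc(C(F)(F)F)c1)C1CCc2ccccc2N1C(=O)c1ccc(Cl)cc1` gives 4230 nM in this assay.

Compound 3 has the lowest number of the three, though compound 1 sits within the scatter of it; only compound 2 lies clearly higher. Compound 4 `O=C(Nc1cc(C(F)(F)F)cc(C(F)(F)F)c1)C1CCc2ccccc2N1C(=O)c1ccccc1Cl` keeps every atom of compound 3 and differs in one place: 2-chlorophenyl in place of 4-chlorophenyl on a carbonyl carbon. Among the measured compounds shown here, no measured pair here isolates this change, so there is nothing to suggest a step beyond the scatter in either direction. The step from compound 3 to compound 4 is expected to be a 1.2-fold higher number from compound 3 to compound 4 (0.07 log units; within the scatter). Compound 4 is therefore estimated at 5000 nM in this assay, with a range from 2000 nM to 13000 nM.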

Compound 4, concentration for 50% growth inhibition: 8040 nM
Compound 4: the middle estimate sits 1.6-fold (0.21 log units) below what was measured; measured number inside the range.
By their numbers in this assay, from the lowest: compounds 3, 1 and 4 (each within the scatter of the next); then compound 2.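

Exchanging 4-chlorophenyl for 2-chlorophenyl on a carbonyl carbon gives a 1.9-fold higher number from compound 3 to compound 4 (0.28 log units; within the scatter) in this assay. This first pair to isolate the change shows that, in this assay, the two placements of the chlorine cannot be told apart at this position. Nothing available explains the numbers for this pair.

The compounds shown leave open whether a step beyond the scatter would appear with a different group on the carbonyl carbon, such as an aminophenyl or a carboxyphenyl. They also leave open whether a bromine in place of the chlorine would read the same.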